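Replacing the silicon group of compound 2 with a triazole

The compounds below may be only part of what the source reports. "The series", "measured", "known", "first", "only" and "open" are said of these compounds alone.

In a functional assay on SMMC-7721 cells (Homo sapiens) for antiproliferative activity, read by MTT assay, with a stated time of 48 h (on this read-out higher numbers stand for weaker inhibition and lower numbers for stronger inhibition), compound 1 `COC/C1=C/C[C@](C)(CCC=C(C)C)/C=C/[C@@H](OC(=O)C=C(C)C)[C@](C)(O)/C=C/C1=O` gives 11000 nM and compound 2 `CC[Si](CC)(CC)C/C1=C/C[C@](C)(CCC=C(C)C)/C=C/[C@@H](OC(=O)C=C(C)C)[C@](C)(O)/C=C/C1=O` gives 3460 nM, the lower of the two numbers and so the stronger inhibition of this pair. The next structure is compound 3 `CC(C)=CCC[C@]1(C)/C=C/[C@@H](OC(=O)C=C(C)C)[C@](C)(O)/C=C/C(=O)/C(Cn2cc(CO)nn2)=C\C1`, which remains unmeasured. The change from compound 2 is a group of 7 heavy atoms (3 carbon, 3 nitrogen, 1 oxygen; one five-membered aromatic ring with 3 hetero atoms) in place of a group of 7 heavy atoms (6 carbon, 1 silicon; no ring), on a saturated chain carbon bound to a double-bonded ring carbon. Going by the values given here, only one measured step bears on this change: a 3.2-fold lower number from compound 1 to compound 2 (0.50 log units; beyond the scatter), a modest step beyond the scatter, made at the same place on the shared core. Among the compounds with values here, that single step gives a size but no rule, and no compound with a ring at this place has been measured. The advantage of compound 2 at 3460 nM is therefore not assumed to carry over in full, and a partial return towards the number of compound 1 at 11000 nM is expected. In this assay, the expected change is a 1.7-fold higher number from compound 2 to compound 3 (0.24 log units; within the scatter), a modest move towards weaker inhibition, although no change at all would not be surprising. For compound 3, the estimated value is 6000 nM, with an expected range of 2000 nM to 18000 nM.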

Compound 3, half-maximal inhibitory concentration: 3560 nM
Beside the measured number, compound 3's estimate is 1.7-fold (0.23 log units) above it; the range from low to high includes it.
By their numbers in this assay, from the lowest: compounds 2 and 3 (each within the scatter of the next); then compound 1.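

In this assay, 4-(hydroxymethyl)-1H-1,2,3-triazol-1-yl in place of the silicon group on the saturated chain carbon bound to a double-bonded ring carbon gives a 1.0-fold higher number from compound 2 to compound 3 (0.01 log units; within the scatter) so the two groups cannot be told apart here, although one has an aromatic ring, a hydrogen-bond donor and hydrogen-bond acceptors and the other has none of these. Against the methoxy compound, the same triazole group gives a 3.1-fold lower number from compound 1 to compound 3 (0.49 log units; beyond the scatter) and the silicon group gives a 3.2-fold lower number from compound 1 to compound 2 (0.50 log units; beyond the scatter) so among these three compounds the step beyond the scatter is no longer tied to silicon and is also reached with a ring at this place. No measurement at hand explains why two such different groups give matching numbers.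

From the compounds shown here alone, it remains open whether the hydroxymethyl part of the group counts or the triazole ring alone suffices, which a triazole carrying an aminomethyl group, a carboxylic acid or a longer alkyl chain in its place would test. Also open, going by these compounds, is whether the count of heavy atoms matters, which a plain ethyl group or a phenyl ring at the same place would help to settle.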